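Acetyl for Isopropylcarbonyl in a Glutamate Receptor Modulator Series

The compounds below may be only part of what the source reports. "The series", "measured", "known", "first", "only" and "open" are said of these compounds alone.

compound 1 `COc1cc(C(=O)O)ccc1OCCCCOc1ccc(C(=O)C(C)C)c(O)c1C`: 73.1%
compound 2 `Cc1c(OCCCCOc2ccc(F)c(C(=O)O)c2)ccc(C(=O)CC(C)(C)C)c1O`: 94.6%
compound 3 `Cc1cc(C(=O)O)ccc1OCCCCOc1ccc(C(=O)C(C)C)c(O)c1C`: 76.9%

In an assay on HEK293 cells for positive allosteric modulation of metabotropic glutamate receptor 2 (Rattus norvegicus), read by thallium flux, with a stated time of 2.5 min (a lower number here means a smaller maximal response, a higher number a larger maximal response), compound 3 stands second highest of the three numbers. Compound 1 lies nearest, and the step of a number 3.8 percentage points higher from compound 1 to compound 3 (within the scatter) is within the scatter. Compound 2 lies above compound 3 by a gap beyond the scatter.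

Compound 4 `CC(=O)c1ccc(OCCCCOc2ccc(C(=O)O)cc2C)c(C)c1O` has not yet been measured. It differs from compound 3 in one place: methyl in place of isopropyl on a carbonyl carbon. Among the measured compounds shown here, the single measured step exchanges methoxy for methyl on an aromatic carbon, a different group at a different place, so no measured step bears on this change. With nothing to point either way, the expected step is one that stays within the scatter: a number 1.9 percentage points lower from compound 3 to compound 4 (within the scatter). Compound 4 is therefore estimated at 75%, with a range from 55% to 95%.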

Compound 4, largest response reached (reported as percent of maximum), in percent of the reference or control that the assay uses: 83.1%
For compound 4 the middle estimate is 8.1 percentage points below the measured one; the range from low to high includes it.
By their numbers in this assay, from the lowest: compounds 1, 3 and 4 (each within the scatter of the next); then compound 2.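

Exchanging isopropylcarbonyl for acetyl in this assay gives a number 6.2 percentage points higher from compound 3 to compound 4 (within the scatter) and is the first change shown at this carbonyl carbon. The maximal response therefore stays within the usual scatter with methyl as with isopropyl, so this place accepts either group in this series. No measurement shown gives a reason for this result. 

What the compounds leave open is how a cyclopropyl or phenyl group on the same carbonyl carbon would read. Going by these compounds, whether methyl and isopropyl would also match on a core carrying methoxy remains open too.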